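Swapping the Cyclopropylamino Group for a Trifluoromethylpiperidine

A few compounds are considered here, and "the series" means these few. Any claim that something is new, unique, unknown or untested is made for them only; others in the source may bear on it.

Measured compounds: compound 1 `COc1ccc(OC)c(-c2cc(-c3ccc(C(=O)N4CCCC4)s3)on2)c1`, compound 2 `COc1ccc(OC)c(-c2cc(-c3ccc(C(=O)N(C)Cc4ccccc4)s3)on2)c1`, compound 3 `COc1ccc(OC)c(-c2cc(-c3ccc(C(=O)NC4CC4)s3)on2)c1`.

In a functional assay on PC-3 cells (Homo sapiens) for cytotoxicity, read by XTT assay, with a stated time of 72 h (a higher number here means a weaker inhibitor, a lower number a stronger inhibitor), compound 1 gives only a limit, > 30000 nM. Compound 2 likewise gives only a limit, > 30000 nM. Within the data shown here, compound 3 gives 7800 nM, the only true number among the three. The steps of an at least 3.8-fold lower number from compound 1 to compound 3 (0.58 log units; beyond the scatter) and an at least 3.8-fold lower number from compound 2 to compound 3 (0.58 log units; beyond the scatter) both show that putting the cyclopropylamino group on the carbonyl carbon in place of a ring-bound or benzyl(methyl) amine lowers the number in this assay. Compound 4 `COc1ccc(OC)c(-c2cc(-c3ccc(C(=O)N4CCC(C(F)(F)F)CC4)s3)on2)c1` reverses that move: 4-(trifluoromethyl)piperidin-1-yl in place of cyclopropylamino on a carbonyl carbon. The nearest measured case, compound 1 with pyrrolidin-1-yl, sits at the limit (the limit of > 30000 nM in this assay, at which 2 of the 3 values shown sit). Compound 4 is therefore expected to give about 30000 nM, between 10000 nM and 100000 nM. The expected step is a 3.8-fold higher number from compound 3 to compound 4 (0.59 log units; beyond the scatter), toward weaker inhibition, quite possibly ending at a limit again.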

Compound 4, half-maximal inhibitory concentration: > 30000 nM
Compound 4 ended at the assay's limit; the forecaster's own chance of this, stated with the estimate: 60%; the middle value sits exactly at the limit.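

In this assay, replacing the cyclopropylamino group with the larger ring gives an at least 3.8-fold higher number from compound 3 to compound 4 (0.58 log units; beyond the scatter), and the true size of this step remains hidden because compound 4 reaches the limit: the limit of > 30000 nM in this assay, at which 3 of the 4 values shown sit. The steps to compound 4 from compound 1 and compound 2 cannot be read, since all three values are limits. Of the four amides on this carbonyl carbon, only compound 3 keeps the amide hydrogen, and only compound 3 gives a true number.

As far as these compounds go, whether that hydrogen matters, or the small ring does, remains open. An ethylamino or cyclobutylamino group at this place could help separate the two.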